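The source may hold more compounds than are shown below. What is called first, only, known or untested is meant among the compounds shown, and "the series" means these compounds.

Measured compounds:
compound 1, `O=C1NCCc2nc(C#Cc3cccc(F)c3)sc21`: in an assay on HEK293 cells for negative allosteric modulation of metabotropic glutamate receptor 5 (Homo sapiens), read by FLIPR, with a stated time of 1 h (a higher number here means a weaker inhibitor, a lower number a stronger inhibitor), compound 1 reaches only the limit > 10000 nM.
compound 2, `CCCCN1CCc2nc(C#Cc3ccccc3)sc2C1`: in this assay compound 2 likewise reaches only the limit > 10000 nM.

Compound 2 therefore stands at the boundary of what this assay can report, and the same is true of compound 1; the limit of > 10000 nM in this assay, at which 2 of the 2 values shown sit, records that both values shown sit there. Going by the values given here, no step between measured compounds can be drawn, and the two limits say only that neither compound showed inhibition that could be quantified. Compound 3, `O=C(C1CC12CCC2)N1CCc2nc(C#Cc3ccccc3)sc2C1`, differs from compound 2 by a group of 8 heavy atoms (7 carbon, 1 oxygen; one three-membered non-aromatic ring of carbon only, one four-membered non-aromatic ring of carbon only) in place of a group of 4 heavy atoms (4 carbon; no ring), on an amine nitrogen in a ring. Among the compounds with values here, no measured step covers this kind of change, so its direction and size are uncertain; it is expected to move toward stronger inhibition, and the step is estimated at an at least 5.0-fold lower number from compound 2 to compound 3 (0.69 log units; beyond the scatter). Compound 3 is expected to give 2000 nM in this assay, within 200 nM to 10000 nM, with a real chance that it again reaches only a limit.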

Compound 3, half-maximal inhibitory concentration: > 10000 nM
Compound 3: no number, only a limit (the forecaster's own chance of this, stated with the estimate: 35%); middle value at least 5.0-fold (0.69 log units) away from the limit.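

Compound 3 gives only a limit in this assay, as compound 2 does, so no step from compound 2 to compound 3 can be read: the limit of > 10000 nM in this assay, at which 3 of the 3 values shown sit.

The compounds shown leave open whether any group on the amine nitrogen in a ring can give inhibition that can be quantified in this assay.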